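A chloro-to-methyl swap on one aromatic carbon

A few compounds are considered here, and "the series" means these few. Any claim that something is new, unique, unknown or untested is made for them only; others in the source may bear on it.

Of the compounds shown here, three have been measured in an assay on Sf9 cells for inhibition of Amine oxidase [flavin-containing] B (Homo sapiens), with stated times of 15 min and 60 min; on this read-out higher numbers stand for weaker inhibition and lower numbers for stronger inhibition. Compound 1 `Cc1cc(OCc2cccc(F)c2)ccc1CN[C@@H](C)C(N)=O` carries an open-chain amide and in this assay gives 69 nM. Compound 2 `NC(=O)[C@@H]1CCN1Cc1ccc(OCc2cccc(F)c2)cc1`, whose amide sits on a small ring, gives 21 nM. Compound 3 `NC(=O)[C@@H]1CCN1Cc1ccc(OCc2cccc(F)c2)cc1Cl` adds a chloro group to the aromatic ring of compound 2, and compound 3 gives 35 nM. Among these three numbers compound 3 stands second highest; its nearest neighbour is compound 2 and its furthest is compound 1, and both gaps lie within the scatter, so none of the three can be ranked against the others. Among the measured compounds shown here, the only step that changes a single spot is a 1.7-fold higher number from compound 2 to compound 3 (0.22 log units; within the scatter).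

Compound 4 `Cc1cc(OCc2cccc(F)c2)ccc1CN1CC[C@H]1C(N)=O` differs from compound 3 in one place: methyl in place of chloro on an aromatic carbon. For the measured compounds named here, the step that bears on this is the one from compound 2 to compound 3, which stayed within the scatter, and a swap of one small group for another on the same carbon gives no reason to expect more. Compound 1 also carries a methyl group on its aromatic ring and gives 69 nM, but since it differs from compound 4 in a second place as well, its number can only hint. Compound 4 is therefore expected to give about 35 nM, within a range from 15 nM to 85 nM, an expected step of no change at the digits printed from compound 3 to compound 4 (within the scatter).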

Compound 4, half-maximal inhibitory concentration: 258 nM
The estimate for compound 4 lay 7.4-fold (0.87 log units) below the measured number; the measured number lies above the stated range.
By their numbers in this assay, from the lowest: compounds 2, 3 and 1 (each within the scatter of the next, the first and the last beyond it); then compound 4.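

This aromatic carbon, ortho to a (2-carbamoylazetidin-1-yl)methyl group, proves sensitive to which group it carries: in this assay, methyl in place of chloro gives a 7.4-fold higher number from compound 3 to compound 4 (0.87 log units; beyond the scatter), and methyl in place of hydrogen gives a 12-fold higher number from compound 2 to compound 4 (1.09 log units; beyond the scatter), whereas chloro in place of hydrogen gave only a 1.7-fold higher number from compound 2 to compound 3 (0.22 log units; within the scatter), so two groups of one heavy atom each are not interchangeable here. With the methyl group held in place, the side chain also counts, as 2-carbamoylazetidin-1-yl in place of (1-carbamoylethyl)amino gives a 3.7-fold higher number from compound 1 to compound 4 (0.57 log units; beyond the scatter). Nothing available explains why methyl and chloro part ways on this carbon.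

The compounds shown leave open how other groups on this carbon would fall relative to hydrogen, chloro and methyl, for instance a bromo, a methoxy or a nitrile group. They also leave open whether the open-chain (1-carbamoylethyl)amino side chain of compound 1 would show the same difference between methyl and chloro, as no chloro partner of compound 1 appears among them.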